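The source may hold more compounds than are shown below. What is called first, only, known or untested is meant among the compounds shown, and "the series" means these compounds.

Measured in an ADME assay on the whole organism (Rattus norvegicus), at a dose of 0.5 mg/kg by the intravenous route; on this read-out lower numbers stand for lower exposure and higher numbers for higher exposure at the dose given:
Compound 1 `CC1CN(c2cnc3c(C(F)(F)F)nn(C(C)c4ccc(Cl)cc4Cl)c3n2)CCC1N1CCCCC1` gives 148 ng.h/mL
Compound 2 `Cc1nn(C(C)c2ccc(Cl)cc2Cl)c2nc(N3CCC(N4CCCCC4)C(C)C3)cnc12` gives 217 ng.h/mL

Within the data shown here, compound 2 stands level with compound 1 on these two numbers, and the only measured step between them is a 1.5-fold higher number from compound 1 to compound 2 (0.17 log units; within the scatter) for methyl in place of trifluoromethyl on an aromatic carbon. Compound 3 `CC1CN(c2cnc3c(C#N)nn(C(C)c4ccc(Cl)cc4Cl)c3n2)CCC1N1CCCCC1` changes that same carbon again, with cyano in place of methyl on an aromatic carbon as the difference. Among the measured compounds shown here, no measured compound carries cyano, so the evidence is indirect. For the measured compounds named here, the one relevant swap, compound 1 to compound 2, stayed within the scatter, and no shift beyond the scatter is expected here. The expected step is a 1.3-fold lower number from compound 2 to compound 3 (0.11 log units; within the scatter) and nothing more is claimed for it. For compound 3 the estimate is 170 ng.h/mL with 70 ng.h/mL to 400 ng.h/mL as its expected range.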

Compound 3, area under the concentration-time curve: 82 ng.h/mL
The estimate for compound 3 lay 2.1-fold (0.32 log units) above the measured number; the measured number falls inside the stated range.
By their numbers in this assay, from the lowest: compounds 3, 1 and 2 (each within the scatter of the next, the first and the last beyond it).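

In this assay, this aromatic carbon of the shared core now gives a step beyond the scatter: cyano in place of methyl yields a 2.6-fold lower number from compound 2 to compound 3 (0.42 log units; beyond the scatter), whereas the earlier swap on the same carbon stayed within it. Cyano in place of trifluoromethyl yields a 1.8-fold lower number from compound 1 to compound 3 (0.26 log units; within the scatter), which lies within the scatter, so only the methyl and cyano compounds can be told apart here, and only modestly. Nothing available here explains that difference at this position.

The compounds shown leave open how a primary amide, a chlorine or an ethyl group on this carbon would read. They also leave open whether the step from methyl to cyano would recur with something other than the 1-(2,4-dichlorophenyl)ethyl group on the shared core.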